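The compounds below may be only part of what the source reports. "The series", "measured", "known", "first", "only" and "open" are said of these compounds alone.

In a functional assay on HeLa cells (Homo sapiens) for antiproliferative activity, read by cell counting, with a stated time of 3 days (a lower number here means a stronger inhibitor, a higher number a weaker inhibitor), compound 1 `CC(Nc1ccccc1Oc1cccc(F)c1)=C1C(=O)CC(c2ccccc2)CC1=O` gives 550 nM, compound 2 `CC(Nc1ccccc1Oc1ccc(Cl)cc1)=C1C(=O)CC(c2ccccc2)CC1=O` gives 500 nM, and compound 3 `COc1ccc(Oc2ccccc2NC(C)=C2C(=O)CC(c3ccccc3)CC2=O)cc1` gives 160 nM. Compound 2 thus holds the second highest of the three numbers: the step of a 1.1-fold lower number from compound 1 to compound 2 (0.04 log units; within the scatter) lies within the scatter, while a 3.1-fold lower number from compound 2 to compound 3 (0.49 log units; beyond the scatter) is a modest move toward stronger inhibition. Compound 4 `CC(Nc1ccccc1Oc1ccc(C(C)O)cc1)=C1C(=O)CC(c2ccccc2)CC1=O` differs from compound 2 by 1-hydroxyethyl in place of chloro on an aromatic carbon. For the measured compounds named here, no measured step involves 1-hydroxyethyl; the only step that replaces chloro at this place is a 3.1-fold lower number from compound 2 to compound 3 (0.49 log units; beyond the scatter), so a modest downward step in this assay is expected, with wide uncertainty. Compound 4 is therefore estimated at 280 nM, with a range of 100 nM to 800 nM. That estimate means a 1.8-fold lower number from compound 2 to compound 4 (0.25 log units; within the scatter).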

Compound 4, half-maximal inhibitory concentration: 75 nM
Estimate against measurement, compound 4: 3.7-fold (0.57 log units) above, and the stated range ends above it.
By their numbers in this assay, from the lowest: compound 4; then compound 3; then compounds 2 and 1 (each within the scatter of the next).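

In this assay, this place on the ring, para to a large group, allows a gain beyond what methoxy gave: 1-hydroxyethyl, which brings a hydrogen-bond donor that chloro lacks, gives a 6.7-fold lower number from compound 2 to compound 4 (0.82 log units; beyond the scatter) and also a 2.1-fold lower number from compound 3 to compound 4 (0.33 log units; beyond the scatter). Setting 4-(1-hydroxyethyl)phenyl in place of 3-fluorophenyl gives a 7.3-fold lower number from compound 1 to compound 4 (0.87 log units; beyond the scatter), which makes compound 4 the strongest of the four. Nothing measured here explains this gain.

As far as these compounds go, whether it comes from the hydroxyl or from the carbons of 1-hydroxyethyl stays open. An ethyl, a hydroxymethyl or an aminomethyl group at this place would help separate the two.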